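This account rests on a few compounds, and the source may have more. Where it says the series, first, only, none or still open, it means among the compounds named here.

Compound 1 `COc1cc(-c2nnc(SCc3ccc([N+](=O)[O-])cc3)o2)ccc1O` in a functional assay on cells (T-cell, Mus musculus, strain BALB/c) for inhibition, read by MTT assay, with stated times of 24 h and 72 h; on this read-out higher numbers stand for weaker inhibition and lower numbers for stronger inhibition: 14200 nM
Compound 2 `COc1cccc(CSc2nnc(-c3ccc(O)c(OC)c3)o2)c1` in this assay: 7410 nM

Of these two numbers compound 2 carries the lower one, but the two values lie within the scatter of each other, so no order between compound 1 and compound 2 can be read from them. Compound 3 `COc1cc(-c2nnc(SCc3ccc(Br)cc3)o2)ccc1O` has not been measured in this assay. It differs from compound 2 in one place: 4-bromophenyl in place of 3-methoxyphenyl on a saturated chain carbon bound to a sulfur. Among the measured compounds shown here, no step between measured compounds bears on this change, so in this assay no step beyond the scatter is expected, in either direction. For compound 3 the value expected in this assay is 9000 nM, with a range from 3000 nM to 30000 nM. The step this estimate means, a 1.2-fold higher number from compound 2 to compound 3 (0.08 log units; within the scatter), is expected to stay within the scatter.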

Compound 3, half-maximal inhibitory concentration: 8830 nM
The estimate for compound 3 lay 1.0-fold (0.01 log units) above the measured number, within the range that was stated.
By their numbers in this assay, from the lowest: compounds 2, 3 and 1 (each within the scatter of the next).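

On a saturated chain carbon bound to a sulfur, 4-bromophenyl in place of 3-methoxyphenyl leaves this assay within the scatter (a 1.2-fold higher number from compound 2 to compound 3 (0.08 log units; within the scatter)). Bromo in place of nitro on an aromatic carbon also stays within it (a 1.6-fold lower number from compound 1 to compound 3 (0.21 log units; within the scatter)), so neither single change separates these compounds. No supporting measurement bears on this result.

Still open, on these data alone, is whether an amine or a carboxylic acid in place of 4-bromophenyl at this carbon would give a step beyond the scatter. The same question holds for a longer chain there.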